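The compounds below may be only part of what the source reports. "The series", "measured", "known", "first", "only" and "open" are said of these compounds alone.

Compound 1 `CCc1cccc(NS(=O)(=O)c2ccc(N3CCNC3=O)cc2)c1`: 82 nM
Compound 2 `COc1ccc(NS(=O)(=O)c2ccc(N3CCNC3=O)cc2)cc1`: 580 nM

In a functional assay on M21 cells (Homo sapiens) for antiproliferative activity, read by sulforhodamine B assay, with a stated time of 48 h (on this read-out lower numbers stand for stronger inhibition and higher numbers for weaker inhibition), compound 2 has the higher of the two numbers, which marks it as the weaker inhibitor of the pair. Compound 3 `COc1ccccc1NS(=O)(=O)c1ccc(N2CCNC2=O)cc1` has 2-methoxyphenyl in place of 4-methoxyphenyl on a sulfonamide nitrogen. For the measured compounds named here, only one measured step bears on this change: a 7.1-fold higher number from compound 1 to compound 2 (0.85 log units; beyond the scatter). Going by the values given here, that step also changed the group on the sulfonamide nitrogen, but it replaced 3-ethylphenyl, and no measured pair compares two methoxyphenyl groups. It shows that this group matters, yet it gives no direction for the new change. No step beyond the scatter is therefore expected in this assay, and the estimated step, slightly upward, is a 1.3-fold higher number from compound 2 to compound 3 (0.11 log units; within the scatter). For compound 3 the expected value is 750 nM, with an estimated range of 200 nM to 2800 nM.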

Compound 3, half-maximal inhibitory concentration: 300 nM
The estimate for compound 3 lay 2.5-fold (0.40 log units) above the measured number, within the range that was stated.
By their numbers in this assay, from the lowest: compound 1; then compounds 3 and 2 (each within the scatter of the next).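

In this assay, 2-methoxyphenyl in place of 4-methoxyphenyl on the sulfonamide nitrogen gives a 1.9-fold lower number from compound 2 to compound 3 (0.29 log units; within the scatter), so the two methoxyphenyl groups cannot be told apart on this read-out. With a 3.7-fold higher number from compound 1 to compound 3 (0.56 log units; beyond the scatter), the 3-ethylphenyl group of compound 1 now stands apart from both methoxyphenyl groups, and compound 1 is the strongest inhibitor of the three. No measurement shown accounts for these numbers.

The compounds shown leave open whether the ethyl group itself or its place on the phenyl ring sets compound 1 apart. They also leave open how an aminophenyl group, a carboxyphenyl group or a phenyl ring with a chain longer than ethyl would fare on the sulfonamide nitrogen.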